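This account rests on a few compounds, and the source may have more. Where it says the series, first, only, none or still open, it means among the compounds named here.

Of the compounds shown here, two built on the same core have been measured in an assay for inhibition of Dihydrofolate reductase (Rattus norvegicus); on this read-out higher numbers stand for higher potency (the scale is a negative logarithm) and lower numbers for lower potency. Compound 1 `COC(=O)c1ccc(N2C(N)=NC(N)=NC2(C)C)cc1` gives 4.26, while compound 2 `CC1(C)N=C(N)N=C(N)N1c1ccc(I)cc1` gives 6.28, the higher of the two numbers. For the measured compounds named here, the single measured step, a number 2.02 log units higher from compound 1 to compound 2 (beyond the scatter), is large and concerns iodo in place of methoxycarbonyl. Compound 3 `CC1(C)N=C(N)N=C(N)N1c1ccc(Br)cc1` has not yet been measured and differs from compound 2 at one point: bromo in place of iodo on an aromatic carbon. Going by the values given here, no measured step concerns bromo against iodo, so the one known step cannot be carried over directly; it only shows where the large gain between compound 1 and compound 2 came from. For compound 3 the expected step is accordingly small, a number 0.18 log units lower from compound 2 to compound 3 (within the scatter), within the usual scatter. Compound 3 is estimated at 6.1, with a range from 5.6 to 6.6.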

Compound 3, logarithm of the reciprocal of the active concentration, log(1/C): 6.24
Compound 3: the middle estimate sits 0.14 log units below what was measured, and the stated range covers the measured number.
By their numbers in this assay, from the lowest: compound 1; then compounds 3 and 2 (each within the scatter of the next).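

In this assay, bromo in place of iodo on this aromatic carbon gives a number 0.04 log units lower from compound 2 to compound 3 (within the scatter) so the read-out does not separate these two halogens at this position. The large gain over the methoxycarbonyl compound is therefore not unique to iodo, since bromo in its place gives a number 1.98 log units higher from compound 1 to compound 3 (beyond the scatter) and thus a second large step at the same carbon. Nothing measured here explains why either halogen gives this result.

The compounds shown cover only two halogens and one ester at this position, so it remains open whether chloro or fluoro would stay level with them. A methyl group, an amine or a carboxylic acid at the same carbon would show whether the higher numbers extend beyond halogens.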